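Chain Length and Cytotoxicity of Sulfoxide Isothiocyanates

This account rests on a few compounds, and the source may have more. Where it says the series, first, only, none or still open, it means among the compounds named here.

Measured compounds:
compound 1, `CC(C)[S+]([O-])CCCCN=C=S`, 9420 nM
compound 2, `CC(C)[S+]([O-])CCCN=C=S`, 18100 nM
compound 3, `[O-][S+](CCCCCN=C=S)Cc1ccccc1`, 7010 nM

All three compounds were tested in a functional assay on SH-SY5Y cells (Homo sapiens) for cytotoxicity, read by MTT assay, with a stated time of 72 h; on this read-out higher numbers stand for weaker inhibition and lower numbers for stronger inhibition. Compound 2 gives 18100 nM and compound 1 gives 9420 nM; the step between them is a 1.9-fold lower number from compound 2 to compound 1 (0.28 log units; within the scatter), which means the two numbers cannot be told apart with confidence. The change behind that step is a group of 4 heavy atoms (2 carbon, 1 nitrogen, 1 sulfur; no ring) in place of a group of 3 heavy atoms (1 carbon, 1 nitrogen, 1 sulfur; no ring), on a saturated chain carbon, three bonds along the chain from a sulfur. Compound 3 gives 7010 nM in this assay; its number is within the scatter of compound 1 but beyond the scatter of compound 2. The difference between the core of compound 3 and the core of compound 2 is not broken down here.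

Compound 4, `[O-][S+](CCCCCCN=C=S)Cc1ccccc1`, has not yet been measured. It differs from compound 3 by a group of 4 heavy atoms (2 carbon, 1 nitrogen, 1 sulfur; no ring) in place of a group of 3 heavy atoms (1 carbon, 1 nitrogen, 1 sulfur; no ring), on a saturated chain carbon, five bonds along the chain from a sulfur. For the measured compounds named here, this is the same kind of change as the one from compound 2 to compound 1, but not the same: in the earlier pair the group sits three bonds along the chain from a sulfur, while in compound 4 it sits five bonds along the chain from a sulfur. Because the earlier step was a 1.9-fold lower number from compound 2 to compound 1 (0.28 log units; within the scatter), the step from compound 3 to compound 4 in this assay is expected to be of similar small size, estimated at a 1.6-fold lower number from compound 3 to compound 4 (0.19 log units; within the scatter). Compound 4 is therefore expected to give about 4500 nM, estimated to lie between 2000 nM and 11000 nM; this rests on one prior pair only.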

Compound 4, half-maximal inhibitory concentration: 7630 nM
Compound 4: middle estimate off by 1.7-fold (0.23 log units), on the low side, and the stated range covers the measured number.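

In this assay, the same change on the core of compound 3 gives a very small step: a 1.1-fold higher number from compound 3 to compound 4 (0.04 log units; within the scatter). Set beside the earlier step on the other core, it gives no sign that the change behaves differently from one core to the other: the same change on two cores in this assay, a 1.9-fold lower number (0.28 log units; within the scatter) from compound 2 to compound 1 and a 1.1-fold higher number (0.04 log units; within the scatter) from compound 3 to compound 4, 2.1-fold (0.32 log units) apart, within the scatter of two such steps This supports only a modest conclusion: the two cores cannot be told apart in their response to this change, but neither step on its own can be told apart from repeat-measurement noise, so the pairs do not show that the change has any real effect on either core, nor that a fixed effect carries over, and the comparison also rests on just two pairs, with the change three bonds along the chain from a sulfur in one and five bonds along the chain from a sulfur in the other.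

The compounds shown leave open whether a longer chain on either core would move the number beyond the scatter. They also leave open how the cores of compound 1 and compound 3 compare with the chain held the same, and whether an amine or a carboxylic acid in place of the isothiocyanate would keep the cytotoxicity.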